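This account rests on a few compounds, and the source may have more. Where it says the series, first, only, none or still open, it means among the compounds named here.

In an assay on cells for inhibition of S-adenosylmethionine decarboxylase proenzyme (Homo sapiens), read by mass spectrometry, at pH 7.2, tested at 180 uM (a higher number here means more inhibition at the concentration tested (going by the name of the read-out), a lower number less inhibition), the three measured analogues lie close together: compound 1 `Cc1cc(Nc2cc(Cl)cc(C#N)c2)nc(N)n1` gives 29%, compound 2 `Cc1cc(Nc2cc(Cl)cc(C(F)(F)F)c2)nc(N)n1` gives 39%, and compound 3 `Cc1cc(Nc2cc(Cl)cc(-c3ccoc3)c2)nc(N)n1` gives 30%. On these numbers compound 3 stands second highest of three, with a number 1 percentage points higher from compound 1 to compound 3 (within the scatter) and a number 9 percentage points lower from compound 2 to compound 3 (within the scatter), both within the scatter. Compound 4 `Cc1cc(Nc2cc(Cl)cc(-c3ccsc3)c2)nc(N)n1` differs from compound 3 by thiophen-3-yl in place of furan-3-yl on an aromatic carbon. Going by the values given here, no measured step exchanges one five-membered aromatic ring for another; the nearest comparisons are the replacements of the cyano group, a number 10 percentage points higher from compound 1 to compound 2 (within the scatter) and a number 1 percentage points higher from compound 1 to compound 3 (within the scatter), neither beyond the scatter. In this assay the expected step is therefore no change at the digits printed from compound 3 to compound 4 (within the scatter), not beyond the scatter. Compound 4 is estimated at 30%, with a range from 18% to 42%.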

Compound 4, a percentage reported as inhibition, at one concentration (the size of the read-out at that concentration, not a potency): 30%
The estimate for compound 4 equals the measured number at the digits printed; the range from low to high includes it.
By their numbers in this assay, from the lowest: compounds 1, 3, 4 and 2 (each within the scatter of the next).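

In this assay, the exchange of one five-membered aromatic ring for another at this position can now be read directly: no change at the digits printed from compound 3 to compound 4 (within the scatter) and the sulfur ring matches the oxygen ring at the digits printed. Against the other groups at this position, a number 9 percentage points lower from compound 2 to compound 4 (within the scatter) and a number 1 percentage points higher from compound 1 to compound 4 (within the scatter), so no step here lies beyond the scatter. No measured evidence bears on this result.

From the compounds shown here alone, whether any group at this position can move the number beyond the scatter stays open, for example an amine, a carboxylic acid or a longer alkyl chain. Going by these compounds, with one tested concentration, potency also stays open.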